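A few compounds are considered here, and "the series" means these few. Any claim that something is new, unique, unknown or untested is made for them only; others in the source may bear on it.

Measured compounds:
compound 1 `Fc1ccc(C(SCCNC2CCN(Cc3ccc(Cl)cc3)CC2)c2ccc(F)cc2)cc1`: 45.5 nM
compound 2 `O=C(c1ccc(F)cc1)N1CCC(NCCSC(c2ccc(F)cc2)c2ccc(F)cc2)CC1`: 32.1 nM
compound 3 `O=C(c1cc2ccccc2[nH]1)N1CCC(NCCSC(c2ccc(F)cc2)c2ccc(F)cc2)CC1`: 1130 nM

In an assay on membranes from Cortex for displacement of a labelled ligand from Sigma non-opioid intracellular receptor 1 (Cavia porcellus), read by scintillation counting, with a stated time of 120 min (on this read-out higher numbers stand for weaker inhibition and lower numbers for stronger inhibition), compound 1 stands second highest of the three numbers; compound 2 is nearest, with a 1.4-fold lower number from compound 1 to compound 2 (0.15 log units; within the scatter), and compound 3 is furthest, with a 25-fold higher number from compound 1 to compound 3 (1.40 log units; beyond the scatter). Compound 3 is also far from compound 2, with a 35-fold higher number from compound 2 to compound 3 (1.55 log units; beyond the scatter).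

Compound 4 `Fc1ccc(C(SCCNC2CCN(Cc3cc4ccccc4[nH]3)CC2)c2ccc(F)cc2)cc1` is not yet measured. It differs from compound 1 by 1H-indol-2-yl in place of 4-chlorophenyl on a saturated chain carbon bound to an amine nitrogen in a ring. The amine nitrogen in the ring thus keeps its saturated chain carbon, and only the aromatic group on that carbon changes.

Within the data shown here, the steps that bear on this are those into compound 3, where the 1H-indol-2-yl group arrives together with a carbonyl; both were large. The step into compound 2, which brings a carbonyl without the indole, lay within the scatter, so the carbonyl alone does not account for the rise in compound 3. The indole appears to carry at least part of it, but compound 4 lacks the carbonyl, so the full size seen in compound 3 need not transfer. A step upward, beyond the scatter but smaller than in compound 3, is expected, with wide uncertainty.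

For compound 4 the expected value in this assay is 160 nM, within 45 nM to 600 nM, meaning an estimated 3.5-fold higher number from compound 1 to compound 4 (0.55 log units; beyond the scatter).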

Compound 4, inhibition constant: 205 nM
Compound 4: the middle estimate sits 1.3-fold (0.11 log units) below what was measured, and the stated range covers the measured number.
By their numbers in this assay, from the lowest: compounds 2 and 1 (each within the scatter of the next); then compound 4; then compound 3.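

In this assay, the 1H-indol-2-yl group raises the number beyond the scatter even with no carbonyl on the ring nitrogen (a 4.5-fold higher number from compound 1 to compound 4 (0.65 log units; beyond the scatter)), so the indole does not need the carbonyl to weaken inhibition at this position. The (1H-indol-2-yl)methyl group is nonetheless better tolerated than (1H-indol-2-yl)carbonyl (a 5.5-fold lower number from compound 3 to compound 4 (0.74 log units; beyond the scatter)), yet a carbonyl is not enough on its own to give a high number, as compound 2, with (4-fluorophenyl)carbonyl, stands on the low side of compound 4 (a 6.4-fold higher number from compound 2 to compound 4 (0.81 log units; beyond the scatter)). No measurement on hand accounts for either effect.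

Still open, going by these compounds, is how a carbonyl acts with a simple aromatic group, since compound 1 and compound 2 differ in the halogen as well as in the carbonyl, and a 4-fluorobenzyl or (4-chlorophenyl)carbonyl group on the same ring nitrogen would separate the two changes. Also open, on these data alone, is whether the rise follows the indole's ring hydrogen or only the larger ring system, which a 1-methyl-1H-indol-2-yl or 2-naphthyl group in the same place would distinguish.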